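From hydroxy to methoxy on a shared core

A few compounds are considered here, and "the series" means these few. Any claim that something is new, unique, unknown or untested is made for them only; others in the source may bear on it.

In a functional assay on SJ-G2 cells (Homo sapiens) for cytotoxicity, read by MTT assay, with a stated time of 72 h (on this read-out lower numbers stand for stronger inhibition of growth and higher numbers for weaker inhibition of growth), compound 1 `N#C/C(=C/c1ccc(Cl)cc1)C(=O)c1ccc[nH]1` gives 53000 nM. Compound 2 `N#C/C(=C/c1ccc(O)cc1)C(=O)c1ccc[nH]1` gives < 10000 nM, which is a limit of the assay and not a number. Compound 2 therefore has no exact place on this scale.

Compound 3 `COc1ccc(/C=C(/C#N)C(=O)c2ccc[nH]2)cc1` differs from compound 2 at one place: methyl in place of hydrogen on an oxygen on an aromatic ring. This is methyl in place of hydrogen on an oxygen on an aromatic ring, or hydroxy to methoxy. Going by the values given here, only one measured step bears on this change: an at least 5.3-fold lower number from compound 1 to compound 2 (0.72 log units; beyond the scatter), with hydroxy in place of chloro on an aromatic carbon. That step is bounded by a limit, so it indicates a direction more firmly than a size. With the hydroxy capped, compound 3 is expected to give back part of that step, moving to a somewhat higher number in this assay while staying short of the value of compound 1, 53000 nM. With a single step as a guide, this expectation is loose. The estimated step is an at least 1.6-fold higher number from compound 2 to compound 3 (0.20 log units; that floor lies within the scatter). For compound 3 the expected value is 16000 nM, with an estimated range from 5000 nM to 50000 nM.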

Compound 3, concentration for 50% growth inhibition: < 10000 nM
Compound 3 ended at the assay's limit; the forecaster's own chance of this, stated with the estimate: 30%; at least 1.6-fold (0.20 log units) between middle value and limit.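

In this assay compound 3 gives < 10000 nM, which is a limit of the assay and not a number. Replacing the chloro with methoxy gives an at least 5.3-fold lower number from compound 1 to compound 3 (0.72 log units; beyond the scatter), a step that is beyond the scatter and matches in size the one already seen for hydroxy, so at this position the lower number does not depend on the hydrogen on the oxygen, which the methyl replaces. The step for hydroxy to methoxy itself cannot be read, and so the two oxygen-bearing compounds cannot be ranked against each other: the limit of < 10000 nM in this assay, at which 2 of the 3 values shown sit.

Going by these compounds, how far the true values of compound 2 and compound 3 lie past that limit remains open, and with it whether the methyl changes anything at all in this assay. Also open, on these data alone, is whether a longer chain on the same oxygen, such as ethoxy, or a different group in the place of the chloro, such as an amine or a carboxylic acid, would keep the number on the same side of compound 1.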